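The source may hold more compounds than are shown below. What is called first, only, known or untested is meant among the compounds shown, and "the series" means these compounds.

Going by the values given here, the three compounds measured so far share one core and differ only in the group on a single aromatic carbon. Compound 1 `Cc1nc(N)c2nc(-c3ccccc3)sc2n1` carries a methyl there, compound 2 `Nc1nc(-c2ccccc2)nc2sc(-c3ccccc3)nc12` a phenyl, and compound 3 `Nc1nc(-c2cccc(CO)c2)nc2sc(-c3ccccc3)nc12` a 3-(hydroxymethyl)phenyl. In a functional assay on CHO cells for antagonist activity at adenosine receptor A2b (Homo sapiens), read by cAMP accumulation, with a stated time of 10 min (on this read-out higher numbers stand for weaker inhibition and lower numbers for stronger inhibition), compound 1 gives > 30000 nM, which is a limit of this assay rather than a number. Compound 2 gives > 30000 nM, likewise a limit. Compound 3 gives > 30000 nM, again a limit, so compound 3 stands no differently from its two companions on the numbers shown. The steps a step that the two limits leave unreadable from compound 1 to compound 2, a step that the two limits leave unreadable from compound 1 to compound 3 and a step that the two limits leave unreadable from compound 2 to compound 3 thus cannot be sized in either direction. Among the compounds with values here, the only evidence bearing on them is the limit of > 30000 nM in this assay, at which 3 of the 3 values shown sit.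

Compound 4 `Nc1nc(-c2ccc(CO)cc2)nc2sc(-c3ccccc3)nc12` differs from compound 3 by 4-(hydroxymethyl)phenyl in place of 3-(hydroxymethyl)phenyl on an aromatic carbon. Since every measured step began and ended at a limit, none of them shows a shift that could guide this move. The step that the limit leaves unreadable from compound 3 to compound 4 is therefore expected to be essentially none beyond the scatter, with a further limit the most likely outcome. Compound 4 is expected to give about 40000 nM in this assay, within a range from 10000 nM to 200000 nM.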

Compound 4, half-maximal inhibitory concentration: > 30000 nM
Compound 4: only a limit was reported (the forecaster's own chance of this, stated with the estimate: 85%); the middle value lies beyond the limit too.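

Compound 4 gives > 30000 nM in this assay and that is a limit, not a number. The steps to compound 4 from compound 1, compound 2 and compound 3 therefore cannot be read: the limit of > 30000 nM in this assay, at which 4 of the 4 values shown sit. The compounds shown leave open how strongly any of them inhibits, and which group on that aromatic carbon, if any, would give a value that is a number rather than a limit.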